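Swapping phenethyl for allyloxy in an antiproliferative series

The compounds below may be only part of what the source reports. "The series", "measured", "known", "first", "only" and "open" are said of these compounds alone.

Compound 1 `Cc1cc(=O)c(O)c(C(c2ccc(OCc3ccc([N+](=O)[O-])cc3)cc2)c2oc(C)cc(=O)c2O)o1`: > 50000 nM
Compound 2 `Cc1cc(=O)c(O)c(C(c2ccc(CCc3ccccc3)cc2)c2oc(C)cc(=O)c2O)o1`: 27200 nM

Among the measured compounds shown here, in a functional assay on U-87MG ATCC cells for antiproliferative activity against U-87 MG (Homo sapiens), read by MTT assay (a lower number here means a stronger inhibitor, a higher number a weaker inhibitor), compound 2 gives 27200 nM, the only true number so far. The entry for compound 1, > 50000 nM, is a limit.

Compound 3 `C=CCOc1ccc(C(c2oc(C)cc(=O)c2O)c2oc(C)cc(=O)c2O)cc1` carries allyloxy in place of phenethyl on an aromatic carbon, para to a large group: allyloxy in place of phenethyl on an aromatic carbon. For the measured compounds named here, one measured step bears on this place, an at least 1.8-fold lower number from compound 1 to compound 2 (0.26 log units; that floor lies within the scatter), and its floor lies within the scatter. No step beyond the scatter is therefore expected in this assay, in either direction. The estimated change is a 1.1-fold higher number from compound 2 to compound 3 (0.04 log units; within the scatter). Compound 3 is expected at 30000 nM, with an estimated range of 12000 nM to 70000 nM.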

Compound 3, half-maximal inhibitory concentration: 30900 nM
For compound 3 the middle estimate is 1.0-fold (0.01 log units) below the measured one, within the range that was stated.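

Replacing phenethyl with allyloxy removes an aromatic ring and brings in an oxygen, yet it gives a 1.1-fold higher number from compound 2 to compound 3 (0.06 log units; within the scatter) in this assay, so this para position shows no response to that large change in the group. The other step, an at least 1.6-fold lower number from compound 1 to compound 3 (0.20 log units; that floor lies within the scatter), has a floor that also lies within the scatter. Compound 1 is known only as a limit, so that comparison has no true size: the limit of > 50000 nM in this assay, at which 1 of the 3 values shown sits.

Nothing shown yet moves the number beyond the scatter at this position. From the compounds shown here alone, whether an amine or a carboxylic acid on this aromatic carbon would do so remains open.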